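A Benzylpyrazole in Place of the Pyridine Oxide

The compounds below may be only part of what the source reports. "The series", "measured", "known", "first", "only" and "open" are said of these compounds alone.

The measured compounds, in an assay on CHO cells for displacement of a labelled ligand from Substance-P receptor (Homo sapiens), in the presence of a further agent that is not named here; on this read-out lower numbers stand for stronger inhibition and higher numbers for weaker inhibition:
compound 1, `C[C@@H](O[C@H]1CN2C(=O)C=C(c3ccc(F)cc3)CC2[C@@H]1c1ccc(F)cc1)c1cc(C(F)(F)F)cc(C(F)(F)F)c1`, 100 nM
compound 2, `C[C@@H](O[C@H]1CN2C(=O)C=C(c3cc[n+]([O-])cc3)CC2[C@@H]1c1ccc(F)cc1)c1cc(C(F)(F)F)cc(C(F)(F)F)c1`, 2.1 nM
compound 3, `C[C@@H](O[C@H]1CN2C(=O)C=C(c3ccc[n+]([O-])c3)CC2[C@@H]1c1ccc(F)cc1)c1cc(C(F)(F)F)cc(C(F)(F)F)c1`, 2.3 nM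

Compound 3 has the second highest of the three numbers in this assay. Its nearest neighbour is compound 2, which lies within the scatter of it; its furthest is compound 1, with a number higher by a 43-fold lower number from compound 1 to compound 3 (1.64 log units; beyond the scatter).

Compound 4, `C[C@@H](O[C@H]1CN2C(=O)C=C(c3cnn(Cc4ccccc4)c3)CC2[C@@H]1c1ccc(F)cc1)c1cc(C(F)(F)F)cc(C(F)(F)F)c1`, differs from compound 3 by a group of 12 heavy atoms (10 carbon, 2 nitrogen; one five-membered aromatic ring with 2 hetero atoms, one six-membered aromatic ring of carbon only) in place of a group of 7 heavy atoms (5 carbon, 1 nitrogen, 1 oxygen; one six-membered aromatic ring with 1 hetero atom), on a double-bonded ring carbon. Among the measured compounds shown here, no measured step swaps the pyridine N-oxide ring for a group of this kind. For the measured compounds named here, the steps that bear on it are a 48-fold lower number from compound 1 to compound 2 (1.68 log units; beyond the scatter) and a 43-fold lower number from compound 1 to compound 3 (1.64 log units; beyond the scatter), both large and both seen when the fluorophenyl group gave way to one of the N-oxide rings, while a 1.1-fold higher number from compound 2 to compound 3 (0.04 log units; within the scatter) showed the two N-oxide placements to be within the scatter of each other. Compound 4 keeps neither N-oxide ring, so a large part of that gain is expected to be given back, though not necessarily all of it, since the entering group still differs from the fluorophenyl of compound 1.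

For compound 4 the expected step is therefore an 11-fold higher number from compound 3 to compound 4 (1.04 log units; beyond the scatter), an upward one. The estimate for compound 4 in this assay is 25 nM, with a range from 5 nM to 150 nM.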

Compound 4, half-maximal inhibitory concentration: 66 nM
Beside the measured number, compound 4's estimate is 2.6-fold (0.42 log units) below it; the measured number falls inside the stated range.
By their numbers in this assay, from the lowest: compounds 2 and 3 (each within the scatter of the next); then compounds 4 and 1 (each within the scatter of the next).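

Compound 4 shows that the low numbers at this double-bonded ring carbon do not survive every change away from 4-fluorophenyl: in this assay, the 1-benzyl-1H-pyrazol-4-yl group loses the ground held by both N-oxide rings (a 29-fold higher number from compound 3 to compound 4 (1.46 log units; beyond the scatter); a 31-fold higher number from compound 2 to compound 4 (1.50 log units; beyond the scatter)), and both steps are large. Set against the 4-fluorophenyl group itself, the same group stays within the scatter (a 1.5-fold lower number from compound 1 to compound 4 (0.18 log units; within the scatter)), so compound 4 and compound 1 sit level although the entering group is larger and carries a five-membered aromatic ring with hetero atoms. Among these four compounds, then, a hetero atom in the ring at this position is not enough for a low number, and only the two pyridine N-oxide rings give one, with compound 4 as the case that goes against any wider reading.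

On these data alone, it remains open whether a plain pyridine ring, or a 1-methyl-1H-pyrazol-4-yl group in place of the benzyl-bearing one, would stay with compound 1 or come closer to compound 2 and compound 3. Nothing measured here accounts for the size of these steps.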